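Rank of the chain on the aromatic nitrogen carbon

The compounds below may be only part of what the source reports. "The series", "measured", "known", "first", "only" and "open" are said of these compounds alone.

Measured compounds:
compound 1 `Cn1sc2cc(OCc3cccc(-c4ccc(Cl)c(C(=O)O)c4)c3)ccc2c1=O` — 74.7%
compound 2 `CC(C)Cn1sc2cc(OCc3cccc(-c4ccc(Cl)c(C(=O)O)c4)c3)ccc2c1=O` — 76.2%
compound 3 `O=C(O)c1cc(-c2cccc(COc3ccc4c(=O)n(CC5CC5)sc4c3)c2)ccc1Cl` — 38.4%

All three share the same core and differ only at the saturated chain carbon bound to the aromatic nitrogen. In an assay on HEK293 cells for positive allosteric modulation of metabotropic glutamate receptor 2 (Rattus norvegicus), read by thallium flux (on this read-out higher numbers stand for larger maximal responses and lower numbers for smaller maximal responses), compound 1 and compound 2 sit within the scatter of each other, a number 1.5 percentage points higher from compound 1 to compound 2 (within the scatter). Compound 3 stands lowest of the three, and both of its steps are beyond the scatter: a number 36.3 percentage points lower from compound 1 to compound 3 (beyond the scatter) and a number 37.8 percentage points lower from compound 2 to compound 3 (beyond the scatter).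

Compound 4 `CC(C)CCn1sc2cc(OCc3cccc(-c4ccc(Cl)c(C(=O)O)c4)c3)ccc2c1=O` is not yet measured. Compared with compound 3 the change is isobutyl in place of cyclopropyl on a saturated chain carbon bound to an aromatic nitrogen. For the measured compounds named here, the step that bears on it most directly is the one from compound 2 to compound 3, which runs isopropyl to cyclopropyl and was large in the downward direction; the step from compound 1 to compound 3 was of the same size. The change to compound 4 reverses that: a ring of carbon leaves and an open chain one carbon longer than that of compound 2 enters. A large upward step is therefore expected in this assay for compound 4, of roughly the size seen in the two steps into compound 3, a number 33.6 percentage points higher from compound 3 to compound 4 (beyond the scatter).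

Compound 4 is estimated at 72%, with a range of 55% to 85%.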

Compound 4, largest response reached (reported as percent of maximum), in percent of the reference or control that the assay uses: 67.3%
For compound 4 the middle estimate is 4.7 percentage points above the measured one; the range from low to high includes it.
By their numbers in this assay, from the lowest: compound 3; then compounds 4, 1 and 2 (each within the scatter of the next).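

In this assay the change from cyclopropyl to isobutyl on a saturated chain carbon bound to an aromatic nitrogen gives a number 28.9 percentage points higher from compound 3 to compound 4 (beyond the scatter) and so shows that the low response of compound 3 does not carry over to a longer open chain at this position. The isopentyl group of compound 4 also cannot be told apart from the smaller chains, with a number 8.9 percentage points lower from compound 2 to compound 4 (within the scatter) and a number 7.4 percentage points lower from compound 1 to compound 4 (within the scatter) so that compounds 1, 2 and 4 form a single level, and among the four compounds only the cyclopropylmethyl group of compound 3 stands apart from it. No measurement at hand accounts for the separate position of compound 3.

From the compounds shown here alone, whether the drop belongs to the three-membered ring alone or to any ring at this place stays open, and a cyclobutyl or cyclopentyl group on the same chain carbon would separate the two cases. Also open, going by these compounds, are how much longer the open chain can grow before the response in this assay changes, and whether a terminal amine or hydroxyl on that chain is tolerated.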